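A few compounds are considered here, and "the series" means these few. Any claim that something is new, unique, unknown or untested is made for them only; others in the source may bear on it.

Measured so far:
compound 1, `CCCC(C)n1c(=O)c(C)nc2c(-c3ccc(Cl)cc3Cl)ccnc21`, gives 62 nM;
compound 2, `CCOc1cc(Cl)c(-c2ccnc3c2nc(C)c(=O)n3C(CC)C2CC2)cc1C`, gives 2 nM;
compound 3, `CC[C@H](C1CC1)n1c(=O)c(C)nc2c(-c3cc(F)c(OC)cc3Cl)ccnc21`, gives 1.7 nM.

These numbers come from a functional assay for antagonist activity at corticotropin-releasing factor receptor 1 (Rattus norvegicus); on this read-out lower numbers stand for stronger inhibition and higher numbers for weaker inhibition. Compound 1 stands highest of the three, so it is the weakest inhibitor among them; compound 2 and compound 3 both lie far lower, well beyond the usual scatter. Compound 4, `CC[C@@H](C1CC1)n1c(=O)c(C)nc2c(-c3ccc(Cl)cc3Cl)ccnc21`, has not been measured yet. It differs from compound 1 in one place: 1-cyclopropylpropyl in place of 1-methylbutyl on an aromatic nitrogen. Among the measured compounds shown here, compound 2 and compound 3 carry that same 1-cyclopropylpropyl group on their aromatic nitrogen, though each also differs from compound 1 elsewhere, so no single step isolates this change. Still, because compound 2 gives 2 nM and compound 3 gives 1.7 nM, a lower number is expected for compound 4. The expected step is a 4.1-fold lower number from compound 1 to compound 4 (0.62 log units; beyond the scatter), beyond the scatter. Compound 4 is therefore estimated at 15 nM, between 4 nM and 50 nM.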

Compound 4, half-maximal inhibitory concentration: 7.4 nM
For compound 4 the middle estimate is 2.0-fold (0.31 log units) above the measured one; the measured number falls inside the stated range.
By their numbers in this assay, from the lowest: compounds 3 and 2 (each within the scatter of the next); then compound 4; then compound 1.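

Among the compounds shown here, with only this group changed on the aromatic nitrogen, 1-cyclopropylpropyl in place of 1-methylbutyl gives an 8.4-fold lower number from compound 1 to compound 4 (0.92 log units; beyond the scatter). This shows that the change alone lowers the number, something compound 2 and compound 3 could not show, as each also differs from compound 1 elsewhere. No supporting measurement bears on what lies behind this step.

The compounds shown leave open whether the three-membered ring or the extra carbon matters here. A 1-ethylbutyl group, which has no ring, at this position would help separate the two.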